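Swapping the aryl group on a four-membered lactam core

This account rests on a few compounds, and the source may have more. Where it says the series, first, only, none or still open, it means among the compounds named here.

Measured compounds in a functional assay on MCF7 cells (Homo sapiens) for antiproliferative activity, read by MTT assay, with stated times of 24 h and 72 h; a lower number here means a stronger inhibitor, a higher number a weaker inhibitor:
compound 1 `COc1cccc([C@@H]2[C@H](Oc3ccccc3)C(=O)N2c2cc(OC)c(OC)c(OC)c2)c1` gives 171000 nM
compound 2 `COc1cc(N2C(=O)[C@@H](Oc3ccccc3)[C@H]2c2ccc([N+](=O)[O-])cc2)cc(OC)c1OC` gives 63000 nM
compound 3 `CCOC(=O)/C=C/c1ccc([C@@H]2[C@H](Oc3ccccc3)C(=O)N2c2cc(OC)c(OC)c(OC)c2)cc1` gives 87000 nM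

Among these three, compound 1 has the highest number, so it is the weakest inhibitor of the set on paper; compound 3 lies within the scatter of it, and only compound 2 sits clearly apart. The unmeasured compound 4 `COc1cc(N2C(=O)[C@@H](Oc3ccccc3)[C@H]2c2ccc(S(C)(=O)=O)cc2)cc(OC)c1OC` differs from compound 1 in one place: 4-(methylsulfonyl)phenyl in place of 3-methoxyphenyl on a saturated ring carbon.

The step that bears most directly on this change is the one where the same 3-methoxyphenyl was exchanged for 4-nitrophenyl, giving a 2.7-fold lower number from compound 1 to compound 2 (0.43 log units; beyond the scatter). Moving the group on that aromatic carbon from nitro to 2-(ethoxycarbonyl)ethenyl gave a 1.4-fold higher number from compound 2 to compound 3 (0.14 log units; within the scatter), so the identity of the group on the 4-position mattered little there. A modest drop in the number is therefore expected, of the same order as the first step. Compound 4 is estimated at 80000 nM, with a range from 30000 nM to 200000 nM. The expected change is a 2.1-fold lower number from compound 1 to compound 4 (0.33 log units; beyond the scatter).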

Compound 4, half-maximal inhibitory concentration: 62000 nM
The estimate for compound 4 lay 1.3-fold (0.11 log units) above the measured number; the range from low to high includes it.
By their numbers in this assay, from the lowest: compounds 4, 2, 3 and 1 (each within the scatter of the next, the first and the last beyond it).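

In this assay, 4-(methylsulfonyl)phenyl in place of 3-methoxyphenyl on the saturated ring carbon gives a 2.8-fold lower number from compound 1 to compound 4 (0.44 log units; beyond the scatter) and so becomes the second replacement at this carbon, after 4-nitrophenyl, to go beyond the scatter. The group on the aromatic carbon makes no readable difference among the three replacements, with methylsulfonyl in place of nitro giving a 1.0-fold lower number from compound 2 to compound 4 (0.01 log units; within the scatter) and methylsulfonyl in place of 2-(ethoxycarbonyl)ethenyl giving a 1.4-fold lower number from compound 3 to compound 4 (0.15 log units; within the scatter) as well. No measurement is available that could explain why these three groups give such similar results.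

The compounds shown leave open whether an amine or a carboxylic acid in place of methylsulfonyl on the aromatic carbon would stay at this level or move the number beyond the scatter. Also open, on these data alone, is where a plain phenyl, carrying no added group, would fall on this scale.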